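The source may hold more compounds than are shown below. What is called first, only, known or untested is meant among the compounds shown, and "the series" means these compounds.

Of the compounds shown here, three of one series have been tested in a functional assay on the whole organism (strain CF-1) for inhibition, with Mus musculus as the target; a higher number here means that more compound is needed for the effect, a lower number that less compound is needed. Compound 2 `Cc1nnc(CN2CCCC2)n1-c1ccc(Cl)cc1C(=O)c1ccccc1` gives 2 mg/kg in this assay. Compound 1 `Cc1nnc(CN(C)C)n1-c1ccc(Cl)cc1C(=O)c1ccccc1` differs from it by dimethylamino in place of pyrrolidin-1-yl on a saturated chain carbon bound to an aromatic carbon, and in this assay compound 1 gives 1.1 mg/kg, a step of a 1.8-fold lower number from compound 2 to compound 1 (0.26 log units; within the scatter). Compound 3 `Cc1nnc(CN2CCCC2)n1-c1ccc(Cl)cc1C(=O)c1ccccc1Cl` carries a second change on the core, (chloro in place of hydrogen on an aromatic carbon), and in this assay compound 3 gives 4 mg/kg, a step of a 2.0-fold higher number from compound 2 to compound 3 (0.30 log units; within the scatter). Compound 4 `Cc1nnc(CN(C)C)n1-c1ccc(Cl)cc1C(=O)c1ccccc1Cl` has not yet been measured. It differs from compound 3 by dimethylamino in place of pyrrolidin-1-yl on a saturated chain carbon bound to an aromatic carbon, which is the same change that leads from compound 2 to compound 1, made on the core that already carries the chloro of compound 3. Going by the values given here, for compound 4 in this assay a step of a 1.8-fold lower number from compound 3 to compound 4 (0.26 log units; within the scatter) is expected, set beside the earlier one, because a 1.8-fold lower number from compound 2 to compound 1 (0.26 log units; within the scatter) is the only measured instance of this change and it stayed within the scatter. Compound 4 is therefore expected to give about 2.2 mg/kg in this assay, with the range 1.2 mg/kg to 4.5 mg/kg reflecting the uncertainty of a single prior example.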

Compound 4, dose for half-maximal effect: 0.28 mg/kg
Compound 4: middle estimate off by 7.9-fold (0.90 log units), on the high side; the measured number lies below the stated range.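

In this assay, dimethylamino in place of pyrrolidin-1-yl on the core of compound 3 gives a 14-fold lower number from compound 3 to compound 4 (1.15 log units; beyond the scatter), and this step does not match the one seen on the core of compound 2: the same change on two cores in this assay, a 1.8-fold lower number (0.26 log units; within the scatter) from compound 2 to compound 1 and a 14-fold lower number (1.15 log units; beyond the scatter) from compound 3 to compound 4, 7.9-fold (0.90 log units) apart, beyond the scatter of two such steps Chloro in place of hydrogen, read on the core of compound 1, gives a 3.9-fold lower number from compound 1 to compound 4 (0.59 log units; beyond the scatter), and this too differs from the step on the core of compound 2: the same change on two cores in this assay, a 2.0-fold higher number (0.30 log units; within the scatter) from compound 2 to compound 3 and a 3.9-fold lower number (0.59 log units; beyond the scatter) from compound 1 to compound 4, 7.9-fold (0.90 log units) apart, beyond the scatter of two such steps Within these four compounds, the two changes therefore do not act independently, and the size of a step on one core did not carry over to the other, but a single set of four compounds shows neither why this happens nor whether it holds elsewhere in the series.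

The compounds shown leave open whether other amines, such as diethylamino or piperidin-1-yl, would follow dimethylamino or pyrrolidin-1-yl on the two cores. They also leave open whether fluoro in place of chloro would give the same dependence on the amine.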